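This account rests on a few compounds, and the source may have more. Where it says the series, first, only, none or still open, it means among the compounds named here.

Compound 1 `Nc1scc(CN2CCN(C3CCCCCC3)CC2)c1C(=O)c1ccc(Cl)cc1` gives 3.7% in a functional assay on CHO cells with adenosine receptor A1 (Homo sapiens) as the target, read by cAMP accumulation and immunoassay, with a stated time of 6 min, tested at 1 uM; a higher number here means a weaker effect of the compound at the concentration tested, a lower number a stronger effect.
Compound 2 `Nc1scc(CN2CCN(c3cccc4ccccc34)CC2)c1C(=O)c1ccc(Cl)cc1` gives 2.9% in this assay.
Compound 3 `Nc1scc(CN2CCN(c3ccc(F)cc3F)CC2)c1C(=O)c1ccc(Cl)cc1` gives -66% in this assay.

Among these three, compound 3 stands lowest, which here means the strongest effect of the set, and the gap to both of the others is far beyond the usual scatter. The step to the unmeasured compound 4 `Nc1scc(CN2CCN(c3ccc(F)c(F)c3)CC2)c1C(=O)c1ccc(Cl)cc1` keeps every atom and only rearranges the fluorines on the aromatic ring: 3,4-difluorophenyl in place of 2,4-difluorophenyl on an amine nitrogen in a ring.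

Among the measured compounds shown here, no measured step exchanges one difluorophenyl for another, so none bears on this change directly. What is known is that introducing the 2,4-difluorophenyl gave a large drop, a number 69.7 percentage points lower from compound 1 to compound 3 (beyond the scatter) and a number 68.9 percentage points lower from compound 2 to compound 3 (beyond the scatter), whereas a change between two non-fluorinated groups at the same position, a number 0.8 percentage points lower from compound 1 to compound 2 (within the scatter), stayed within the scatter. Compound 4 therefore carries an aromatic group of the same composition, but whether the strong effect of compound 3 depends on where the fluorines sit cannot be told from these data. A number somewhat higher than compound 3, yet still well below compounds 1 and 2, is the expectation, with wide uncertainty: the expected step is a number 31 percentage points higher from compound 3 to compound 4 (beyond the scatter).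

For compound 4 the estimated value in this assay is -35%, expected to fall between -75% and 5%.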

Compound 4, a percentage reported as activity, at one concentration (the size of the read-out at that concentration, not a potency): -78%
For compound 4 the middle estimate is 43 percentage points above the measured one; measured number below the stated range.
By their numbers in this assay, from the lowest: compound 4; then compound 3; then compounds 2 and 1 (each within the scatter of the next).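

Rearranging the two fluorines, with no atom gained or lost, keeps the strong effect on this amine nitrogen in this assay (a number 12 percentage points lower from compound 3 to compound 4 (beyond the scatter)), a modest step towards a stronger effect. The 2,4-difluorophenyl arrangement is therefore not the only one that works here, and the large gaps to the non-fluorinated groups hold for the 3,4-difluorophenyl as well (a number 80.9 percentage points lower from compound 2 to compound 4 (beyond the scatter); a number 81.7 percentage points lower from compound 1 to compound 4 (beyond the scatter)), which makes compound 4 the strongest of the four. Nothing available explains why this arrangement gives the lower number.

Still open is whether fluorine is needed at all, since a plain phenyl, a phenyl with one fluorine and a dichlorophenyl do not appear among these compounds. Each number also comes from a single concentration, so it describes the size of the effect there and not a potency.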